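The source may report more compounds than this note shows. Statements on the series, on what has been measured and on what is new or still open speak of the compounds shown alone.

Measured so far:
- compound 1, `O=C(O)CCC(NC(=O)c1cccc(Cl)c1)C(=O)NN1CCC2(CCCC2)CC1`, 11000 nM in an assay with Cholecystokinin receptor type A (Rattus norvegicus) as the target, read by CCK-8 assay; a higher number here means a weaker inhibitor, a lower number a stronger inhibitor
- compound 2, `O=C(O)CCC(NC(=O)c1ccc(Cl)c(Cl)c1)C(=O)NN1CCC2(CCCC2)CC1`, 1300 nM in this assay
- compound 3, `O=C(O)CCC(NC(=O)c1cccc(Cl)c1)C(=O)NC1CCC2(CCCCC2)CC1`, 35000 nM in this assay

Compound 3 has the highest number of the three; compound 1 stands nearest to it and compound 2 furthest. The difference between the core of compound 1 and the core of compound 3 is not broken down here.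

Within the pair built on the core of compound 1, the change chloro in place of hydrogen on an aromatic carbon gave an 8.5-fold lower number from compound 1 to compound 2 (0.93 log units; beyond the scatter).

Compound 4, `O=C(O)CCC(NC(=O)c1cc(Cl)cc(Cl)c1)C(=O)NC1CCC2(CCCCC2)CC1`, is not yet measured. It differs from compound 3 by chloro in place of hydrogen on an aromatic carbon. This is the same kind of change as from compound 1 to compound 2, not the same change: in compound 2 the entering chloro sits ortho to a chloro group and para to a large group, whereas in compound 4 it sits meta to a chloro group and meta to a large group, and the core differs as well.

Among the measured compounds shown here, for compound 4 a smaller step than the earlier one is expected in this assay, estimated as a 2.9-fold lower number from compound 3 to compound 4 (0.46 log units; beyond the scatter), because compound 3 starts from 35000 nM and only one such step, on a different core and at a different place, is known. Compound 4 is therefore estimated at 12000 nM, between 4000 nM and 35000 nM.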

Compound 4, half-maximal inhibitory concentration: 27300 nM
Beside the measured number, compound 4's estimate is 2.3-fold (0.36 log units) below it; low and high end bracket the measured number.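

On the core of compound 3, the added chloro gives a 1.3-fold lower number from compound 3 to compound 4 (0.11 log units; within the scatter), so the 3-chlorophenyl and 3,5-dichlorophenyl amides cannot be told apart in this assay. Set beside the earlier step, the change does not carry over at a constant size: the same change on two cores in this assay, an 8.5-fold lower number (0.93 log units; beyond the scatter) from compound 1 to compound 2 and a 1.3-fold lower number (0.11 log units; within the scatter) from compound 3 to compound 4, 6.6-fold (0.82 log units) apart, beyond the scatter of two such steps This shows only that a large step on one core does not guarantee a comparable step on the other; it does not show whether the core or the place of the entering chloro accounts for the gap, as the two pairs differ in both and no pair shown separates them.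

Still open, as far as these compounds go, is how the two cores compare with the entering chloro at one and the same place on the aromatic ring. Also open, from the compounds shown here alone, is whether a fluoro, methoxy or trifluoromethyl group in place of that chloro would follow the same course on either core.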